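This account rests on a few compounds, and the source may have more. Where it says the series, first, only, none or still open, it means among the compounds named here.

In an ADME assay on MT4 cells (Homo sapiens) for cytotoxicity, read by MTT assay (on this read-out higher numbers stand for lower toxicity in this test and lower numbers for higher toxicity in this test), compound 3 `O=C(CSc1nc(Cc2c(F)cccc2Cl)cc(=O)[nH]1)c1ccc(F)cc1` gives > 61000 nM, which is a limit and not a number. Compound 2 `O=C(CSc1nc(Cc2c(F)cccc2Cl)cc(=O)[nH]1)c1ccccc1` gives > 13000 nM, also a limit. Compound 4 `COc1ccc(C(=O)CSc2nc(Cc3c(F)cccc3Cl)cc(=O)[nH]2)cc1` differs from compound 3 in one place, with methoxy in place of fluoro on an aromatic carbon, para to a large group: methoxy in place of fluoro on an aromatic carbon. Going by the values given here, the only measured step at this place is a step that the two limits leave unreadable from compound 2 to compound 3, so it offers no size to carry over to the new change. Compound 1 `COc1ccc(C(=O)CSc2nc(Cc3c(Cl)cccc3Cl)cc(=O)[nH]2)cc1`, which carries the 4-methoxyphenyl group but differs elsewhere as well, gives > 11000 nM, likewise a limit. That limit gives no number either, but it leads to the expectation that another limit is quite likely in this assay. The expected change is an at least 1.7-fold lower number from compound 3 to compound 4 (0.24 log units; that floor lies within the scatter), with only a slight lean towards lower numbers and no firm direction. For compound 4 the estimate is 35000 nM, with an expected range from 11000 nM to 100000 nM.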

Compound 4, half-maximal cytotoxic concentration: > 12000 nM
Compound 4: only a limit was reported; the forecaster's own chance of this, stated with the estimate: 70%; the middle value lies beyond the limit too.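

In this assay compound 4 gives > 12000 nM, which is a limit and not a number. Its steps from compound 1, compound 2 and compound 3 cannot be read, as those values are limits too. The compounds shown leave open whether 4-fluorophenyl or 4-methoxyphenyl changes this read-out at all.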